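Three limits and a small change in the chain

A few compounds are considered here, and "the series" means these few. Any claim that something is new, unique, unknown or untested is made for them only; others in the source may bear on it.

Values in an ADME assay on L02 cells (Homo sapiens) for cytotoxicity, read by MTT assay, with a stated time of 72 h (on this read-out higher numbers stand for weaker inhibition and lower numbers for stronger inhibition), each one a limit of the assay and not a number:
Compound 1 `CC(C)/C=C/C(=O)Nc1cccc(Oc2nc(Nc3ccn(C)n3)nc3c2CSCC3)c1` gives > 50000 nM as its limit
Compound 2 `CCC/C=C/C(=O)Nc1cccc(Oc2nc(Nc3cccc(C#N)c3)nc3c2CSCC3)c1` gives > 50000 nM as its limit
Compound 3 `CC(C)=CC(=O)Nc1cccc(Oc2nc(Nc3cccc(C#N)c3)nc3c2CSCC3)c1` gives > 50000 nM as its limit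

Compound 3 therefore has no exact position on this scale, only a limit. It shares that reading with the other two compounds, as the limit of > 50000 nM in this assay, at which 3 of the 3 values shown sit, shows.

Compound 4 `CC(C)/C=C/C(=O)Nc1cccc(Oc2nc(Nc3cccc(C#N)c3)nc3c2CSCC3)c1` follows from compound 3 by one change, 3-methylbut-1-en-1-yl in place of 2-methylprop-1-en-1-yl on a carbonyl carbon and this places 3-methylbut-1-en-1-yl in place of 2-methylprop-1-en-1-yl on a carbonyl carbon.

Going by the values given here, the only measured step that bears on this swap is a step that the two limits leave unreadable from compound 2 to compound 3 and it also exchanges the chain on the carbonyl carbon. It gives no size to carry over, so no shift beyond the scatter, in either direction, is expected in this assay here.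

The expected change is a step that the limit leaves unreadable from compound 3 to compound 4 and it is only an estimate. For compound 4 the estimated value is 60000 nM with an expected range from 30000 nM to 120000 nM and the assay will probably report only a limit again.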

Compound 4, half-maximal inhibitory concentration: > 50000 nM
Compound 4: only a limit was reported; the forecaster's own chance of this, stated with the estimate: 85%; the middle value does not contradict the limit.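

Compound 4 also gives only a limit, like compound 1, compound 2 and compound 3, so no step among these compounds can be read: the limit of > 50000 nM in this assay, at which 4 of the 4 values shown sit.

The compounds shown leave open where each true value lies in this assay, and whether changing the chain on the carbonyl carbon shifts it at all.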